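The source may report more compounds than this note shows. Statements on the series, on what has been measured and on what is new or still open speak of the compounds shown alone.

Measured so far in an ADME assay on the whole organism for pharmacokinetics, with Rattus norvegicus as the target, at a dose of 1 mg/kg by the intravenous route; a higher number here means faster removal of the compound, a lower number slower removal:
- Compound 1 `Cc1cccc2ccc(N3CCC(C(=O)N[C@H]4CCC[C@H]4CCc4ccccc4C(=O)O)CC3)nc12`: 31 mL/min/kg
- Compound 2 `O=C(O)c1ccc(Cl)cc1NC[C@@H]1CCC[C@@H]1NC(=O)C1CCN(c2ccccc2)CC1`: 81 mL/min/kg
- Compound 3 `O=C(O)c1ccc(Cl)cc1NC[C@@H]1CCC[C@@H]1NC(=O)C1CCN(c2ccc(C(F)(F)F)cc2)CC1`: 40 mL/min/kg

Compound 1 and compound 3 lie within the scatter of each other, while compound 2 gives a clearly higher number than compound 1.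

The next compound is compound 4 `O=C(O)c1ccccc1CC[C@@H]1CCC[C@@H]1NC(=O)C1CCN(c2ccc(OC(F)(F)F)cc2)CC1`, still unmeasured. The change from compound 1 is 4-(trifluoromethoxy)phenyl in place of 8-methylquinolin-2-yl on an amine nitrogen in a ring.

Within the data shown here, no measured step makes this exact swap, so the evidence is indirect. Among the measured compounds shown here, the one measured step, a 2.0-fold lower number from compound 2 to compound 3 (0.31 log units; beyond the scatter), puts trifluoromethyl in place of hydrogen on an aromatic carbon. It shows that a substituted phenyl group on that nitrogen can come with the lower number, and compound 3 at 40 mL/min/kg sits within the scatter of compound 1. Compound 4 also carries a substituted phenyl group there, so no change beyond the scatter is expected, and the estimated step is a 1.2-fold higher number from compound 1 to compound 4 (0.06 log units; within the scatter). For compound 4 the expected value is 36 mL/min/kg, with an estimated range from 18 mL/min/kg to 70 mL/min/kg.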

Compound 4, clearance: 17 mL/min/kg
The estimate for compound 4 lay 2.1-fold (0.33 log units) above the measured number; the whole stated range lies above it.
By their numbers in this assay, from the lowest: compounds 4, 1 and 3 (each within the scatter of the next, the first and the last beyond it); then compound 2.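

In this assay, the swap on the amine nitrogen in a ring gives a 1.8-fold lower number from compound 1 to compound 4 (0.26 log units; within the scatter). So, on the core of compound 1, the two-ring 8-methylquinolin-2-yl can give way to 4-(trifluoromethoxy)phenyl, which has a single aromatic ring of carbon only, and the two numbers remain within the scatter of each other. No measurement shown here explains this result.

From the compounds shown here alone, it remains open whether the loss of the second ring or the presence of the trifluoromethoxy group matters more at this position. On this core, a pyridin-2-yl group, with one aromatic ring containing a ring nitrogen, or a 4-methoxyphenyl group would help to separate these two parts of the change.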